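Chain extension on the ester tail of a quinazoline series

The compounds below may be only part of what the source reports. "The series", "measured", "known", "first", "only" and "open" are said of these compounds alone.

Compound 2 `CCCCCCCCCCCCCCCCOC(=O)CCC(=O)N1CCN(CCCOc2cc3c(Nc4ccc(F)c(Cl)c4)ncnc3cc2OC)CC1` carries the longer ester chain of the two measured compounds; in a functional assay on A549 cells (Homo sapiens) for cytotoxicity, read by MTT assay, with a stated time of 24 h, tested at 10 uM (on this read-out higher numbers stand for a weaker effect at the one concentration tested and lower numbers for a stronger effect), compound 2 gives 97.7%, the higher of two numbers, with compound 1 `CCCCCCCOC(=O)CCC(=O)N1CCN(CCCOc2cc3c(Nc4ccc(F)c(Cl)c4)ncnc3cc2OC)CC1` giving 89.1%. Within the data shown here, the one step on record, a number 8.6 percentage points higher from compound 1 to compound 2 (within the scatter), lengthened the same chain without moving the read-out beyond the scatter. Compound 3 `CCCCCCCCCCCCCCCCCCCOC(=O)CCC(=O)N1CCN(CCCOc2cc3c(Nc4ccc(F)c(Cl)c4)ncnc3cc2OC)CC1` extends that chain further: propyl in place of hydrogen on a saturated chain carbon, ten or more bonds along the chain from an oxygen next to a carbonyl group. Among the measured compounds shown here, no other step bears on it. The expected change is therefore none beyond the scatter, a number 1.7 percentage points lower from compound 2 to compound 3 (within the scatter). Compound 3 is estimated at 96%, within 85% to 104%.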

Compound 3, a percentage reported as activity, at one concentration (the size of the read-out at that concentration, not a potency): 94.5%
Compound 3: middle estimate off by 1.5 percentage points, on the high side, and the stated range covers the measured number.
By their numbers in this assay, from the lowest: compounds 1, 3 and 2 (each within the scatter of the next).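

In this assay propyl in place of hydrogen on a saturated chain carbon, ten or more bonds along the chain from an oxygen next to a carbonyl group, gives a number 3.2 percentage points lower from compound 2 to compound 3 (within the scatter) and the full dodecyl extension gives a number 5.4 percentage points higher from compound 1 to compound 3 (within the scatter) so the ester chain now spans three lengths with no step beyond the scatter. Extension past compound 2 therefore adds no separation on this read-out, and neither does the longest span in the set. No measurement on hand offers an explanation for this flat result.

Open, on these data alone, is whether a chain shorter than that of compound 1 would move the read-out beyond the scatter. Also open, as far as these compounds go, is whether an amine or a carboxylic acid at the chain end would do so.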